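The source may report more compounds than this note shows. Statements on the series, on what has been measured and on what is new or still open speak of the compounds shown alone.

Compound 2 `O=C1C(Nc2cccc(Cl)c2)=CC(=O)c2c1nc1n2[C@H]2OC[C@@H](O)[C@H]2OC1` is measured in a functional assay on ECa-109 cells for inhibition, with ECa-109 cell line (Homo sapiens) as the target, read by sulforhodamine B assay (a lower number here means a stronger inhibitor, a higher number a weaker inhibitor), at 3080 nM. Compound 3 `CCc1ccc(NC2=CC(=O)c3nc4n(c3C2=O)[C@H]2OC[C@@H](O)[C@H]2OC4)cc1` gives 3080 nM in this assay, level with compound 2 at the digits shown, and compound 1 `Cc1ccc(NC2=CC(=O)c3nc4n(c3C2=O)[C@H]2OC[C@@H](O)[C@H]2OC4)cc1` gives 3480 nM; all three sit within the scatter of one another, so none can be called stronger. For the measured compounds named here, the single change with two measured ends, a 1.1-fold lower number from compound 1 to compound 3 (0.05 log units; within the scatter), stays within the scatter. Compound 4 `O=C1C(Nc2ccc(I)cc2)=CC(=O)c2c1nc1n2[C@H]2OC[C@@H](O)[C@H]2OC1` differs from compound 2 by 4-iodophenyl in place of 3-chlorophenyl on an amine nitrogen. Going by the values given here, no measured step exchanges one halogen for another, so the only guide is that across compounds 1, 2 and 3 the changes of the aryl group left this assay unmoved. The step of a 1.0-fold lower number from compound 2 to compound 4 (0.01 log units; within the scatter) is expected to stay within the scatter as well. Compound 4 is therefore estimated at 3000 nM, with a range from 1200 nM to 7500 nM.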

Compound 4, half-maximal inhibitory concentration: 2530 nM
Estimate against measurement, compound 4: 1.2-fold (0.07 log units) above; measured number inside the range.
By their numbers in this assay, from the lowest: compounds 4, 2, 3 and 1 (each within the scatter of the next).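

On the amine nitrogen, 4-iodophenyl in place of 3-chlorophenyl gives a 1.2-fold lower number from compound 2 to compound 4 (0.09 log units; within the scatter) in this assay, so a change of halogen at this position also stays within the scatter. The halogen and its place on the aryl ring change together in this step, so their contributions cannot be read separately. No evidence on any property bears on this result.

A 4-chlorophenyl or 3-iodophenyl group would separate the two changes. Also open, on these data alone, is whether the level response holds for a cyclohexyl, pyridyl or carboxylic acid-bearing phenyl group on that nitrogen.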